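Amide aryl swap in a thiazolidinedione series: compound 3 to compound 4

The source may report more compounds than this note shows. Statements on the series, on what has been measured and on what is new or still open speak of the compounds shown alone.

Compound 1, `Cc1ccc(NC(=O)COc2ccc3cc(/C=C4/SC(=O)NC4=O)ccc3c2)cc1`: in an assay on isolated protein for inhibition of histone deacetylase 8 (Homo sapiens), with a stated time of 1 h (on this read-out higher numbers stand for weaker inhibition and lower numbers for stronger inhibition), compound 1 gives 9000 nM.
Compound 2, `Cc1ccc(NC(=O)COc2ccc3cc(/C=C4/SC(=O)NC4=O)ccc3c2)cc1Cl`: in this assay compound 2 reaches only the limit > 50000 nM.
Compound 3, `O=C(COc1ccc2cc(/C=C3/SC(=O)NC3=O)ccc2c1)Nc1cccc(Cl)c1`: in this assay compound 3 reaches only the limit > 50000 nM.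

Compound 3 stands at the limit of this assay, not at a number. That limit is the limit of > 50000 nM in this assay, at which 2 of the 3 values shown sit. Within the data shown here, the only readable step into compound 3 is an at least 5.5-fold higher number from compound 1 to compound 3 (0.74 log units; beyond the scatter), so 3-chlorophenyl in place of 4-methylphenyl on the amide-type nitrogen costs a good deal. The step that the two limits leave unreadable from compound 2 to compound 3 cannot be read, as both ends are limits.

Compound 4, `O=C(COc1ccc2cc(/C=C3/SC(=O)NC3=O)ccc2c1)Nc1ccc(Br)cc1`, differs from compound 3 by 4-bromophenyl in place of 3-chlorophenyl on an amide-type nitrogen. Among the measured compounds shown here, no measured step covers a bromine on that ring, and none covers the 4-bromophenyl pattern. Compound 4 is expected to stay weak, with a fair chance of another limit, so the estimate for compound 4 is 30000 nM, ranging from 8000 nM to 50000 nM. The step this estimate implies, an at least 1.6-fold lower number from compound 3 to compound 4 (0.22 log units; that floor lies within the scatter), is expected to be unreadable against the limit at compound 3.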

Compound 4, half-maximal inhibitory concentration: 16000 nM
For compound 4 the middle estimate is 1.9-fold (0.27 log units) above the measured one, within the range that was stated.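

The amide-type nitrogen tolerates a halogen-bearing aryl group: 4-bromophenyl gives an at least 3.1-fold lower number from compound 3 to compound 4 (0.49 log units; beyond the scatter) and an at least 3.1-fold lower number from compound 2 to compound 4 (0.49 log units; beyond the scatter), so a halogen on this ring does not by itself bring the loss seen with the 3-chlorophenyl and 3-chloro-4-methylphenyl groups. Bromo in place of methyl gives a 1.8-fold higher number from compound 1 to compound 4 (0.25 log units; within the scatter), so among the compounds shown the 4-methylphenyl and 4-bromophenyl groups cannot be told apart, while both groups with a 3-chloro pattern end at the limit. The two steps from compound 2 and compound 3 are floors and not full sizes, because both of those compounds stand at a limit: the limit of > 50000 nM in this assay, at which 2 of the 4 values shown sit.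

On these data alone, the step from compound 3 to compound 4 changes both the halogen and the pattern on the ring, so the share of each stays open. A 4-chlorophenyl group would separate the two, and 4-aminophenyl or 4-carboxyphenyl groups would test whether this position accepts anything beyond methyl and bromo.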